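Hydroxy in Place of Hydrogen: From Compound 3 to Compound 4

A few compounds are considered here, and "the series" means these few. Any claim that something is new, unique, unknown or untested is made for them only; others in the source may bear on it.

Compound 3 `Cc1c(C(=O)N/N=C/c2ccccc2)no[n+]1[O-]` shares its core with compound 1 `Cc1c(C(=O)N/N=C/c2ccccn2)no[n+]1[O-]` and compound 2 `Cc1c(C(=O)N/N=C/c2ccc(C(F)(F)F)cc2)no[n+]1[O-]`. In an ADME assay on J774.1 cells (Mus musculus) for cytotoxicity, read by MTT assay, with a stated time of 48 h (a higher number here means a weaker inhibitor, a lower number a stronger inhibitor), compound 3 gives only a limit, > 400000 nM. Compound 1 likewise gives a limit, > 400000 nM. Compound 2 also gives a limit, > 400000 nM. The steps a step that the two limits leave unreadable from compound 1 to compound 3 and a step that the two limits leave unreadable from compound 2 to compound 3 cannot be read because of the limit of > 400000 nM in this assay, at which 3 of the 3 values shown sit. Compound 4 `Cc1c(C(=O)N/N=C/c2ccccc2O)no[n+]1[O-]` differs from compound 3 by hydroxy in place of hydrogen on an aromatic carbon. Among the compounds with values here, no measured step bears on this change, since every value shown sits at the limit. Compound 4 is expected to sit at the same limit, so the estimated step that the limit leaves unreadable from compound 3 to compound 4 is none beyond the scatter. The estimate for compound 4 is 600000 nM, between 300000 nM and 2000000 nM.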

Compound 4, half-maximal inhibitory concentration: 246000 nM
Compound 4: middle estimate off by 2.4-fold (0.39 log units), on the high side; the measured number lies below the stated range.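

Hydroxy in place of hydrogen on this aromatic carbon, ortho to a large group, is the first change shown that yields a readable direction in this assay, with an at least 1.6-fold lower number from compound 3 to compound 4 (0.21 log units; that floor lies within the scatter). Compound 4 is the only compound shown that gives a number rather than a limit. That step is only a floor, and the true size stays unknown because the other compounds sit at a limit: the limit of > 400000 nM in this assay, at which 3 of the 4 values shown sit.

The compounds shown leave open whether a methoxy group, an amine or a carboxylic acid on the same carbon would also give a number. They also leave open whether hydroxy on another carbon of this ring would do so.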